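The compounds below may be only part of what the source reports. "The series", "measured", "known", "first", "only" and "open" are said of these compounds alone.

Three compounds of this series carry a measurement in a functional assay on the whole organism for inhibition, with Rattus norvegicus as the target, at a dose of 30 mg/kg; a lower number here means less inhibition, a higher number more inhibition at the dose given (going by the name of the read-out). Compound 1 `Fc1ccc(-c2nc3cccnc3o2)cc1` gives 27%, compound 2 `Clc1ccc(-c2nc3cccnc3o2)cc1` gives 14%, and compound 3 `Fc1ccc(-c2nc3ncccc3o2)c(F)c1` gives 23%. How the core of compound 1 and the core of compound 3 differ is not broken down here. Compound 1 and compound 2 differ by chloro in place of fluoro on an aromatic carbon; the step is a number 13 percentage points lower from compound 1 to compound 2 (beyond the scatter). Compound 4 `Fc1cc(Cl)ccc1-c1nc2ncccc2o1` is not yet measured; it differs from compound 3 by chloro in place of fluoro on an aromatic carbon. This is the same kind of change, although around the place the entering group now also stands meta to a fluoro group (1 heavy atom). Among the compounds with values here, because the step of a number 13 percentage points lower from compound 1 to compound 2 (beyond the scatter) is the only guide for this change, a step of roughly the same size is expected, a number 10 percentage points lower from compound 3 to compound 4 (within the scatter). Compound 4 is thus estimated at 13%, expected to fall between 0% and 28%.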

Compound 4, a percentage reported as inhibition, in the whole organism at one dose (the size of the read-out at that dose, not a potency): 19%
Compound 4: the middle estimate sits 6 percentage points below what was measured; measured number inside the range.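

On the core of compound 3, chloro in place of fluoro on an aromatic carbon, here meta to a fluoro group, gives a number 4 percentage points lower from compound 3 to compound 4 (within the scatter) in this assay. Set beside the same change on the core of compound 1, the two steps cannot be told apart: the same change on two cores in this assay, a number 13 percentage points lower (beyond the scatter) from compound 1 to compound 2 and a number 4 percentage points lower (within the scatter) from compound 3 to compound 4, 9 percentage points apart, within the scatter of two such steps. Within the data shown here, this agrees with the change carrying over between these two cores, but with one pair per core it does not establish a fixed step size, and only the step on the core of compound 1 lies beyond the scatter.

As far as these compounds go, what an amine or a carboxylic acid at this place would give in this assay remains open. From the compounds shown here alone, whether the step holds on any further core also remains open.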